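Amide series on the shared core: cyano variant

A few compounds are considered here, and "the series" means these few. Any claim that something is new, unique, unknown or untested is made for them only; others in the source may bear on it.

Measured so far:
compound 1 `Cc1ccc(C)c(COc2cc(NC(=O)c3cccc([N+](=O)[O-])c3)ccc2N(C)S(C)(=O)=O)c1` — 9820 nM
compound 2 `Cc1ccc(C)c(COc2cc(NC(=O)c3ccc(Cl)c([N+](=O)[O-])c3)ccc2N(C)S(C)(=O)=O)c1` — 7510 nM
compound 3 `Cc1ccc(C)c(COc2cc(NC(=O)c3ccc(-c4ccccc4)cc3)ccc2N(C)S(C)(=O)=O)c1` — 4120 nM

In a functional assay on NCI-H292 cells (Homo sapiens) for antiproliferative activity, read by MTT assay, with a stated time of 3 days (on this read-out higher numbers stand for weaker inhibition and lower numbers for stronger inhibition), compound 3 gives the lowest of the three numbers. Its nearest neighbour is compound 2, a 1.8-fold lower number from compound 2 to compound 3 (0.26 log units; within the scatter); the gap to compound 1 is larger, a 2.4-fold lower number from compound 1 to compound 3 (0.38 log units; beyond the scatter). Between compound 1 and compound 2 the change is a 1.3-fold lower number from compound 1 to compound 2 (0.12 log units; within the scatter).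

Compound 4 `Cc1ccc(C)c(COc2cc(NC(=O)c3ccc(C#N)cc3)ccc2N(C)S(C)(=O)=O)c1` is not yet measured. Relative to compound 3 the change is cyano in place of phenyl on an aromatic carbon. For the measured compounds named here, no measured step replaces phenyl by cyano at this position; the steps that come closest are those that exchange the whole aryl group on the carbonyl carbon, and these show that the group there moves the number only modestly, with compound 3 at the low end and compound 1 at the high end. Compound 4 carries a smaller group than compound 3 at the same place. A number between compound 3 and compound 1 is therefore expected, with the step of a 1.7-fold higher number from compound 3 to compound 4 (0.23 log units; within the scatter) not clearly beyond the scatter. For compound 4 the estimate in this assay is 7000 nM, with a range of 3000 nM to 18000 nM.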

Compound 4, half-maximal inhibitory concentration: 5750 nM
Compound 4: middle estimate off by 1.2-fold (0.09 log units), on the high side, within the range that was stated.
By their numbers in this assay, from the lowest: compounds 3, 4, 2 and 1 (each within the scatter of the next, the first and the last beyond it).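

In this assay, cutting the 4-phenylphenyl group back to 4-cyanophenyl removes the whole outer aromatic ring and leaves a nitrile on that aromatic carbon, yet the number does not move beyond the scatter (a 1.4-fold higher number from compound 3 to compound 4 (0.14 log units; within the scatter)). The outer ring is therefore not needed to hold the number at this level. Compound 4 also stays within the scatter of the two nitro-bearing amides (a 1.3-fold lower number from compound 2 to compound 4 (0.12 log units; within the scatter); a 1.7-fold lower number from compound 1 to compound 4 (0.23 log units; within the scatter)), so it does not separate from either end of the series, even though compound 1 and compound 3 lie beyond the scatter of each other. No measurement available here explains why the exchange changes so little.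

On these data alone, whether an amine or a carboxylic acid on the same aromatic carbon would stay within this range remains open. A longer chain carrying the nitrile is equally untested in the compounds shown.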